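The source may hold more compounds than are shown below. What is called first, only, known or untested is meant among the compounds shown, and "the series" means these compounds.

Measured compounds in a functional assay on NCI-H322M cells (Homo sapiens) for inhibition, read by sulforhodamine B assay, with a stated time of 48 h; on this read-out higher numbers stand for weaker inhibition of growth and lower numbers for stronger inhibition of growth:
compound 1 `COc1ccc(CNc2nc3cc(N)cc(N)c3nc2-c2ccccc2)cc1OC` gives 22900 nM;
compound 2 `CCOC(=O)[C@H](CCC(=O)O)NC(=O)c1ccc(Sc2nc3cc(N)cc(N)c3nc2-c2ccccc2)cc1` gives 34700 nM;
compound 3 `COc1cc(CNc2nc3cc(N)cc(N)c3nc2-c2ccccc2)cc(OC)c1OC` gives 3020 nM.

Compound 1 stands second highest of the three numbers in this assay. Its nearest neighbour is compound 2, whose number lies within the scatter of that of compound 1, so no order between these two can be read. For the measured compounds named here, its furthest neighbour is compound 3, and the one measured step that bears on the question is a 7.6-fold lower number from compound 1 to compound 3 (0.88 log units; beyond the scatter), a modest change but beyond the scatter.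

Compound 4 `COc1ccc(CNc2nc3cc(N)cc(N)c3nc2-c2ccccc2)cc1` differs from compound 1 by hydrogen in place of methoxy on an aromatic carbon. This is the same kind of change as the step to compound 3, but run in the opposite direction: a methoxy leaves rather than enters. Compound 4 is therefore expected to give a somewhat higher number than compound 1, with the step of a 1.7-fold higher number from compound 1 to compound 4 (0.24 log units; within the scatter) kept smaller than the measured one because a 7.6-fold lower number from compound 1 to compound 3 (0.88 log units; beyond the scatter) concerned a different ring position and the pattern rests on a single pair. For compound 4 the estimate in this assay is 40000 nM, within the range 15000 nM to 100000 nM.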

Compound 4, concentration for 50% growth inhibition: 22900 nM
Compound 4: the middle estimate sits 1.7-fold (0.24 log units) above what was measured; the range from low to high includes it.
By their numbers in this assay, from the lowest: compound 3; then compounds 1, 4 and 2 (each within the scatter of the next).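

In this assay, going from the 3,4-dimethoxyphenyl group to 4-methoxyphenyl gives no change at the digits printed from compound 1 to compound 4 (within the scatter), so at this place, ortho to a methoxy group and meta to a large group, exchanging methoxy for hydrogen leaves the number unmoved. The earlier compounds had shown only a methoxy entering, with a 7.6-fold lower number from compound 1 to compound 3 (0.88 log units; beyond the scatter), and the two steps together show that this exchange does not read alike in every case on this ring. Nothing measured here gives a cause for that contrast.

From the compounds shown here alone, it remains open whether a hydroxyl, a fluorine atom or an amine at this place would read like hydrogen and methoxy. Also open, going by these compounds, is what would happen to the number if the remaining methoxy of the 4-methoxyphenyl group gave way to hydrogen.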